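This account rests on a few compounds, and the source may have more. Where it says the series, first, only, none or still open, it means among the compounds named here.

Measured so far in a functional assay on HT-29 cells (Homo sapiens) for antiproliferative activity, read by sulforhodamine B assay, with a stated time of 48 h; on this read-out lower numbers stand for stronger inhibition and higher numbers for weaker inhibition: compound 1 `CCC(=O)Nc1ccc(S(=O)(=O)Oc2ccccc2C(C)C)cc1` gives 7400 nM; compound 2 `CCCC(=O)Nc1ccc(S(=O)(=O)Oc2ccccc2C(C)C)cc1` gives 4900 nM; compound 3 `CCCC(=O)Nc1ccc(S(=O)(=O)Oc2ccccc2I)cc1` gives 11000 nM.

Compound 2 has the lowest number of the three. The step of a 1.5-fold lower number from compound 1 to compound 2 (0.18 log units; within the scatter) is within the scatter, whereas the step of a 2.2-fold higher number from compound 2 to compound 3 (0.35 log units; beyond the scatter) is beyond it.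

Compound 4 `CC(C)c1ccccc1OS(=O)(=O)c1ccc(NC(=O)C(C)(C)C)cc1` differs from compound 2 by tert-butyl in place of propyl on a carbonyl carbon. Among the compounds with values here, the only measured step touching this chain is a 1.5-fold lower number from compound 1 to compound 2 (0.18 log units; within the scatter), a lengthening of the same chain that stayed within the scatter; the step from compound 2 to compound 3 changes a different part of the molecule and does not bear on this. In this assay compound 4 is therefore expected to move no further than the scatter, an expected step of a 1.1-fold lower number from compound 2 to compound 4 (0.04 log units; within the scatter). Compound 4 is estimated at 4500 nM, within 2000 nM to 10000 nM.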

Compound 4, half-maximal inhibitory concentration: 15000 nM
The estimate for compound 4 lay 3.3-fold (0.52 log units) below the measured number, outside the stated range (above it).
By their numbers in this assay, from the lowest: compounds 2, 1, 3 and 4 (each within the scatter of the next, the first and the last beyond it).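

On this carbonyl carbon the group does matter in this assay: tert-butyl in place of propyl gives a 3.1-fold higher number from compound 2 to compound 4 (0.49 log units; beyond the scatter), and tert-butyl in place of ethyl gives a 2.0-fold higher number from compound 1 to compound 4 (0.31 log units; beyond the scatter). Both steps are modest, yet ethyl to propyl had stayed within the scatter, so among these compounds only the branched tert-butyl group shifts the number clearly upward. Nothing available accounts for this shift. From the compounds shown here alone, whether a longer straight chain or an isopropyl group on this carbonyl carbon would stay near compound 2 remains open. So does whether tert-butyl has the same effect when iodo replaces the isopropyl on the aromatic carbon.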